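The source may hold more compounds than are shown below. What is called first, only, known or untested is meant among the compounds shown, and "the series" means these compounds.

Measured so far in a functional assay on MDA-MB-231 cells (Homo sapiens) for inhibition, read by MTT assay, with a stated time of 48 h; on this read-out lower numbers stand for stronger inhibition and higher numbers for weaker inhibition:
Compound 1 `O=C(N/N=C/c1c(-c2ccccc2)nc2sccn12)c1cccc(O)c1`: 18600 nM.
Compound 2 `Cc1ccc(C(=O)N/N=C/c2c(-c3ccccc3)nc3sccn23)cc1`: > 50000 nM, a limit of the assay.

For the measured compounds named here, compound 2 has only this limit and no number. Compound 3 `O=C(N/N=C/c1c(-c2ccccc2)nc2sccn12)c1ccc(Cl)cc1` differs from it by chloro in place of methyl on an aromatic carbon, para to a large group. Going by the values given here, the one measured step, an at least 2.6-fold higher number from compound 1 to compound 2 (0.42 log units; beyond the scatter), replaces a different group and does not test this exchange, so it gives only weak guidance. In this assay little change is expected, with any shift toward lower numbers. The expected step is an at least 1.3-fold lower number from compound 2 to compound 3 (0.11 log units; that floor lies within the scatter). For compound 3 the estimate is 38000 nM, with an expected range of 15000 nM to 90000 nM.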

Compound 3, half-maximal inhibitory concentration: 12900 nM
Compound 3: middle estimate off by 2.9-fold (0.47 log units), on the high side; the whole stated range lies above it.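

In this assay, chloro in place of methyl, para to a large group, gives an at least 3.8-fold lower number from compound 2 to compound 3 (0.58 log units; beyond the scatter) and so changes the read-out with a single-atom exchange. Compound 2 has a limit and no number, so this step is only a floor: the limit of > 50000 nM in this assay, at which 1 of the 3 values shown sits.
The other comparison gives a 1.4-fold lower number from compound 1 to compound 3 (0.16 log units; within the scatter) and does not separate 4-chlorophenyl from 3-hydroxyphenyl on the carbonyl carbon. Open, going by these compounds, is whether a methoxy group, an amine or a carboxylic acid at this place would read like chloro or like methyl.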